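Chloro in place of cyano: working notes on the series

The source may report more compounds than this note shows. Statements on the series, on what has been measured and on what is new or still open speak of the compounds shown alone.

Values measured in an ADME assay on HeLa cells (Homo sapiens) for cytotoxicity, read by MTT assay, with a stated time of 2 days (a lower number here means that less compound is tolerated, a higher number that more compound is tolerated), for the three compounds so far
- Compound 1 `CCOC(=O)c1sc2cc(Oc3ccnc(C(=O)NC)c3)ccc2c1C` gives > 100000 nM (a limit)
- Compound 2 `CCOC(=O)c1sc2cc(Oc3ccnc(C(=O)NC)c3)ccc2c1N` gives 450 nM
- Compound 3 `CCOC(=O)c1sc2cc(Oc3ccnc(C(=O)NC)c3)ccc2c1C#N` gives > 100000 nM (a limit)

Compound 3 has no number and sits at the limit of > 100000 nM in this assay, at which 2 of the 3 values shown sit. The next change, to compound 4 `CCOC(=O)c1sc2cc(Oc3ccnc(C(=O)NC)c3)ccc2c1Cl`, is chloro in place of cyano on an aromatic carbon, counted as chloro in place of cyano on an aromatic carbon.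

Among the compounds with values here, three measured steps bear on this change. Methyl and cyano cannot be separated, as a step that the two limits leave unreadable from compound 1 to compound 3 shows. Amino alone gives a number, with an at least 220-fold lower number from compound 1 to compound 2 (2.34 log units; beyond the scatter) and an at least 220-fold higher number from compound 2 to compound 3 (2.34 log units; beyond the scatter) as the two large steps. Compound 2 therefore goes against the otherwise flat picture. Chloro is not amino, so a step of that size is not expected in this assay. At most a modest move towards lower numbers is expected, and probably none beyond the scatter. The estimated step is an at least 1.4-fold lower number from compound 3 to compound 4 (0.15 log units; that floor lies within the scatter). For compound 4 the estimate is 70000 nM, with an expected range from 10000 nM to 200000 nM.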

Compound 4, half-maximal cytotoxic concentration: 45600 nM
Compound 4: middle estimate off by 1.5-fold (0.19 log units), on the high side, within the range that was stated.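

In this assay, within the data shown here, compound 4 is the first compound without the amino group to give a number rather than a limit, and the other two remain at that limit: the limit of > 100000 nM in this assay, at which 2 of the 4 values shown sit. Replacing cyano with chloro gives an at least 2.1-fold lower number from compound 3 to compound 4 (0.34 log units; beyond the scatter), and replacing methyl with chloro gives an at least 2.1-fold lower number from compound 1 to compound 4 (0.34 log units; beyond the scatter); each step is a floor, set by a limit on one side. Amino still stands apart, with a 100-fold higher number from compound 2 to compound 4 (2.01 log units; beyond the scatter), so this position now shows a large gap between chloro and amino as well as a smaller, at least modest, one between chloro and the two groups at the limit.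

Going by these compounds, the true values of compound 1 and compound 3 stay open, and with them the full size of both floors. Also open, on these data alone, is whether a methylamino, dimethylamino or hydroxyl group at this position would give numbers nearer to chloro or to amino.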